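The compounds below may be only part of what the source reports. "The series", "measured", "known", "first", "only" and "open" are said of these compounds alone.

Measured in a functional assay on the whole organism with Mus musculus as the target; a higher number here means that more compound is needed for the effect, a lower number that less compound is needed:
- compound 1 `Cc1c(C)c2c(c(C)c1N)CC(C)(CSc1ccncc1)O2`: 19.9 mg/kg
- compound 2 `Cc1c(C)c2c(c(C)c1N)CC(C)(CSc1nccn1C)O2`: 37.1 mg/kg

Compound 2 and compound 1 lie within the scatter of each other, so these two numbers cannot be ranked. Compound 3 `Cc1c(C)c2c(c(C)c1N)CC(C)(CSCCC(=O)O)O2` keeps the shared core and has 2-carboxyethyl in place of 1-methyl-1H-imidazol-2-yl on a sulfur.

Among the compounds with values here, only one measured step bears on this sulfur. That step, a 1.9-fold higher number from compound 1 to compound 2 (0.27 log units; within the scatter), exchanges pyridin-4-yl for 1-methyl-1H-imidazol-2-yl and stays within the scatter. Within the data shown here, no measured compound carries an open chain there, so the data give no direction for the new change, and any forecast remains uncertain. With that single small step as the guide, the expected change is a 1.1-fold higher number from compound 2 to compound 3 (0.03 log units; within the scatter), which means no shift beyond the scatter. The estimate for compound 3 is 40 mg/kg, with an expected range of 13 mg/kg to 120 mg/kg.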

Compound 3, dose for 50% inhibition: 43 mg/kg
Compound 3: middle estimate off by 1.1-fold (0.03 log units), on the low side; low and high end bracket the measured number.
By their numbers in this assay, from the lowest: compounds 1, 2 and 3 (each within the scatter of the next, the first and the last beyond it).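

Setting the open 2-carboxyethyl chain on the sulfur in place of the 1-methyl-1H-imidazol-2-yl ring gives a 1.2-fold higher number from compound 2 to compound 3 (0.06 log units; within the scatter) in this assay, so a ring on this sulfur is not needed for compound 3 to give a measurable dose. Within the data shown here, measured against pyridin-4-yl, the same chain gives a 2.2-fold higher number from compound 1 to compound 3 (0.33 log units; beyond the scatter), the first step at this sulfur to pass the scatter, though only modestly, and so the first pair here that can be ranked. No measurement available here accounts for these small differences.

From the compounds shown here alone, how the length of the chain matters remains open, as a longer chain ending in the same carboxylic acid could show. It is also unknown whether an amine or an amide at the chain end would give a similar dose.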